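The source may report more compounds than this note shows. Statements on the series, on what has been measured and on what is new or still open speak of the compounds shown alone.

Measured compounds:
- compound 1, `COc1ccccc1C(=O)NCc1ccc(CNS(=O)(=O)c2ccccc2F)cc1`: 1 nM
- compound 2, `O=C(NCc1ccc(CNS(=O)(=O)c2cccc(Cl)c2)cc1)c1cccnc1`: 100 nM
- compound 3, `COc1ccccc1C(=O)NCc1ccc(CNS(=O)(=O)c2cccc(F)c2)cc1`: 1000 nM

In an assay on MDA-MB-231 cells for displacement of a labelled ligand from C-X-C chemokine receptor type 4 (Homo sapiens), read by fluorescence and microscopy, with stated times of 10 min and 30 min (a higher number here means that more compound is needed for the effect, a lower number that less compound is needed), compound 3 gives the highest number of the three measured compounds. Compound 2 stands nearest to it, with a lower number, and compound 1 stands furthest away, with the lowest number of the set. Going by the values given here, the one single-point step recorded so far is a 1000-fold higher number from compound 1 to compound 3 (3.00 log units; beyond the scatter); it concerns the position of the fluoro on the sulfonyl-bearing ring, not the identity of the halogen, so it does not bear directly on the step at hand.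

Compound 4, `COc1ccccc1C(=O)NCc1ccc(CNS(=O)(=O)c2cccc(Cl)c2)cc1`, arises from compound 3 by chloro in place of fluoro on an aromatic carbon. Among the compounds with values here, no measured pair isolates this change. Compound 2 carries the same 3-chlorophenyl on the sulfonyl sulfur but a different amide part, so its value can only be read as a loose pointer: compound 2 gives 100 nM against compound 3 at 1000 nM. On that basis a modest downward step, a 3.3-fold lower number from compound 3 to compound 4 (0.52 log units; beyond the scatter), is expected in this assay, with wide uncertainty. Compound 4 is estimated at 300 nM, within 50 nM to 2000 nM.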

Compound 4, effective concentration (reported as EC, without a stated level of effect): 1000 nM
Estimate against measurement, compound 4: 3.3-fold (0.52 log units) below, within the range that was stated.
By their numbers in this assay, from the lowest: compound 1; then compound 2; then compounds 3 and 4 (each within the scatter of the next).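

With the 2-methoxyphenyl amide held constant, chloro in place of fluoro on this aromatic carbon gives no change at the digits printed from compound 3 to compound 4 (within the scatter) in this assay, so 3-fluorophenyl and 3-chlorophenyl on the sulfonyl sulfur cannot be told apart here. Going by these compounds alone, the new compound also gives the first single-place reading on the amide side: with 3-chlorophenyl held constant, 2-methoxyphenyl in place of pyridin-3-yl on a carbonyl carbon gives a 10-fold higher number from compound 2 to compound 4 (1.00 log units; beyond the scatter). The large gap to the 2-fluorophenyl compound appears with either 3-halophenyl group, as a 1000-fold higher number from compound 1 to compound 3 (3.00 log units; beyond the scatter) and a 1000-fold higher number from compound 1 to compound 4 (3.00 log units; beyond the scatter). Nothing available accounts for these steps. Still open, as far as these compounds go, is whether an amine or a carboxylic acid at this ring position would separate from fluoro and chloro, and whether 2-fluorophenyl keeps its low number alongside the pyridin-3-yl amide.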